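Second instance of a methoxy-to-hydrogen step

A few compounds are considered here, and "the series" means these few. Any claim that something is new, unique, unknown or untested is made for them only; others in the source may bear on it.

Compound 1 `COc1cc(-c2cc(/C=C/C(=O)c3ccc(N)cc3)[nH]n2)cc(OC)c1OC` and compound 2 `COc1ccc(-c2cc(/C=C/C(=O)c3ccc(N)cc3)[nH]n2)cc1OC` share one core; compound 3 `COc1cc(C(=O)/C=C/c2cc(-c3cc(OC)c(OC)c(OC)c3)n[nH]2)cc(OC)c1OC` and compound 4 `COc1ccc(-c2cc(/C=C/C(=O)c3cc(OC)c(OC)c(OC)c3)[nH]n2)cc1OC` share another, and the difference between the two cores is not broken down here. In a functional assay on NCI-H226 cells (Homo sapiens) for inhibition, read by sulforhodamine B assay, with a stated time of 48 h (a higher number here means a weaker inhibitor of growth, a lower number a stronger inhibitor of growth), compound 1 gives 3510 nM, compound 2 gives 7380 nM and compound 3 gives 3050 nM. The numbers for compound 3 and compound 1 lie within the scatter of each other, while compound 2 stands beyond the scatter from compound 3. The change from compound 1 to compound 2 is hydrogen in place of methoxy on an aromatic carbon and it produced a 2.1-fold higher number from compound 1 to compound 2 (0.32 log units; beyond the scatter). The change from compound 3 to compound 4 is hydrogen in place of methoxy on an aromatic carbon, the same change at a place described in the same words. Compound 4 is expected to give 6200 nM in this assay, with a range from 3200 nM to 12000 nM. Going by the values given here, this expected step, a 2.0-fold higher number from compound 3 to compound 4 (0.31 log units; beyond the scatter), rests on the single precedent a 2.1-fold higher number from compound 1 to compound 2 (0.32 log units; beyond the scatter).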

Compound 4, concentration for total growth inhibition: 7910 nM
Compound 4: middle estimate off by 1.3-fold (0.11 log units), on the low side, and the stated range covers the measured number.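

In this assay, hydrogen in place of methoxy on an aromatic carbon gives a 2.6-fold higher number from compound 3 to compound 4 (0.41 log units; beyond the scatter), a step in the same direction as the one on the core of compound 1. The change therefore carries from one core to the other in this series, with steps of matching size: the same change on two cores in this assay, a 2.1-fold higher number (0.32 log units; beyond the scatter) from compound 1 to compound 2 and a 2.6-fold higher number (0.41 log units; beyond the scatter) from compound 3 to compound 4, 1.2-fold (0.09 log units) apart, within the scatter of two such steps. Going by these compounds alone, this rests on only two pairs in one assay, so it does not show that the step would hold on any further core, and it gives no reason for the step.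

On these data alone, what a hydroxyl group or a longer alkoxy chain would give in place of this methoxy remains open. Also open, as far as these compounds go, is whether either group would follow the same direction on both cores.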